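A few compounds are considered here, and "the series" means these few. Any claim that something is new, unique, unknown or untested is made for them only; others in the source may bear on it.

Working notes on the series, with the group on the saturated chain carbon as the one varied place. In a physicochemical assay for permeability, using PAMPA (a higher number here means that the compound crosses the layer faster, a lower number that the compound crosses the layer more slowly), compound 1 `Cc1ccc([C@@H](C)Oc2cc3oc(=O)n(CCC(=O)O)c3cc2Cl)nc1` gives 22 nm/s. Compound 2 `C[C@@H](Oc1cc2oc(=O)n(CCC(=O)O)c2cc1Cl)c1ncco1` reads < 3 nm/s, which is a limit of the assay and not a number. Compound 2 thus stands at the limit of < 3 nm/s in this assay, at which 1 of the 2 values shown sits.

Compound 3 `C[C@@H](Oc1cc2oc(=O)n(CCC(=O)O)c2cc1Cl)c1ncccn1` differs from compound 2 by pyrimidin-2-yl in place of 1,3-oxazol-2-yl on a saturated chain carbon bound to an oxygen on an aromatic ring and a saturated chain carbon: pyrimidin-2-yl in place of 1,3-oxazol-2-yl, with the rest of the structure unchanged.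

Among the measured compounds shown here, only one measured step bears on this place: an at least 7.3-fold lower number from compound 1 to compound 2 (0.86 log units; beyond the scatter), beyond the scatter, with 1,3-oxazol-2-yl in place of 5-methylpyridin-2-yl. For the measured compounds named here, that step has only a bound on its size, and no measured step starts from compound 2 or involves pyrimidin-2-yl. In this assay, a small upward step or none beyond the scatter is expected, well short of the size of an at least 7.3-fold lower number from compound 1 to compound 2 (0.86 log units; beyond the scatter). The expected step is an at least 1.3-fold higher number from compound 2 to compound 3 (0.12 log units; that floor lies within the scatter). A reading that is again only a limit is quite possible. Compound 3 is estimated at 4 nm/s, with an expected range of 1.5 nm/s to 12 nm/s.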

Compound 3, apparent permeability: < 3 nm/s
Compound 3 gave a limit, no number; the forecaster's own chance of this, stated with the estimate: 45%; middle value at least 1.3-fold (0.12 log units) away from the limit.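

In this assay compound 3 reads < 3 nm/s, which is a limit of the assay and not a number. Pyrimidin-2-yl in place of 5-methylpyridin-2-yl on the saturated chain carbon gives an at least 7.3-fold lower number from compound 1 to compound 3 (0.86 log units; beyond the scatter), so the fall seen with 1,3-oxazol-2-yl is no longer a single case: a five-membered and a six-membered aromatic ring, each with 2 hetero atoms, both end at the limit. The step between compound 2 and compound 3 cannot be read, so the two groups cannot be ordered, and the values now collect at one point: the limit of < 3 nm/s in this assay, at which 2 of the 3 values shown sit.

On these data alone, how far compound 2 and compound 3 lie beyond the limit stays open, as does whether the step from compound 1 goes with the loss of the methyl group or with the change of ring, as each replacement changes both. A plain pyridin-2-yl group and a 5-methylpyrimidin-2-yl group on the same carbon would separate these two changes, and their place in this assay is not known from the compounds shown.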